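A few compounds are considered here, and "the series" means these few. Any claim that something is new, unique, unknown or untested is made for them only; others in the source may bear on it.

In an assay on HEK293 cells for displacement of a labelled ligand from metabotropic glutamate receptor 5 (Homo sapiens), with a stated time of 2 h (on this read-out higher numbers stand for weaker inhibition and lower numbers for stronger inhibition), compound 1 `Cc1ccccc1C#Cc1ccc2c(n1)CCN(C)C2=O` reaches no number, only the limit > 32000 nM, which is the limit of > 32000 nM in this assay, at which 1 of the 3 values shown sits. Compound 2 `Cc1cccc(C#Cc2ccc3c(n2)CCN(C)C3=O)c1` gives 820 nM, and compound 3 `CN1CCc2nc(C#Cc3cccc(Cl)c3)ccc2C1=O` gives 250 nM. Compound 3 has the lowest of the two numbers shown, compound 2 being nearest through the step of a 3.3-fold lower number from compound 2 to compound 3 (0.52 log units; beyond the scatter). Compound 4 `CN1CCc2nc(C#Cc3ccc(Cl)cc3)ccc2C1=O` differs from compound 3 by 4-chlorophenyl in place of 3-chlorophenyl on a triple-bonded carbon. Moving the group around the ring gave large steps, namely an at least 39-fold lower number from compound 1 to compound 2 (1.59 log units; beyond the scatter) and an at least 120-fold lower number from compound 1 to compound 3 (2.10 log units; beyond the scatter), while swapping methyl for chloro gave the modest 3.3-fold lower number from compound 2 to compound 3 (0.52 log units; beyond the scatter). Because an at least 39-fold lower number from compound 1 to compound 2 (1.59 log units; beyond the scatter) and an at least 120-fold lower number from compound 1 to compound 3 (2.10 log units; beyond the scatter) were large, a sizeable shift in this assay is expected, most likely towards a higher number. Compound 4 is estimated at 2500 nM (range 300 nM to 20000 nM), an expected step of a 10-fold higher number from compound 3 to compound 4 (1.00 log units; beyond the scatter).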

Compound 4, inhibition constant: 6150 nM
Beside the measured number, compound 4's estimate is 2.5-fold (0.39 log units) below it, within the range that was stated.
By their numbers in this assay, from the lowest: compound 3; then compound 2; then compound 4. At a limit, above all of these: compound 1.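

In this assay, among these compounds, 4-chlorophenyl in place of 3-chlorophenyl gives a 25-fold higher number from compound 3 to compound 4 (1.39 log units; beyond the scatter), the first step here in which the same group only changes its place on the phenyl ring, and that alone makes a large difference. Compound 4 also stands on the weaker side of the 3-methylphenyl compound, with a 7.5-fold higher number from compound 2 to compound 4 (0.88 log units; beyond the scatter). It still stands clear of the 2-methylphenyl compound, with an at least 5.2-fold lower number from compound 1 to compound 4 (0.71 log units; beyond the scatter), though that step is only a bound, as compound 1 gives a limit and not a number: the limit of > 32000 nM in this assay, at which 1 of the 4 values shown sits. As far as these compounds go, how 2-chlorophenyl or 4-methylphenyl would compare remains open, as does the effect of a methoxy group or a nitrile on the phenyl ring.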